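Ring size at the amide nitrogen: tetrahydroquinoline to indoline

A few compounds are considered here, and "the series" means these few. Any claim that something is new, unique, unknown or untested is made for them only; others in the source may bear on it.

Compound 3 `CS(=O)(=O)c1ccc(C(=O)NCCC(=O)N2CCCc3ccccc32)cc1[N+](=O)[O-]` is the only one of the three measured compounds that returns a number in an ADME assay on HepG2 cells (Homo sapiens) for cytotoxicity, read by CellTiter-Glo and ATP content, with a stated time of 72 h; on this read-out lower numbers stand for an effect already at smaller amounts and higher numbers for an effect only at larger amounts of compound: compound 3 gives 10500 nM. Compound 1 `CS(=O)(=O)c1ccc(C(=O)N2CCC(C(=O)N3CCN(c4ccc(F)cc4)CC3)CC2)cc1[N+](=O)[O-]` reaches only a limit of this assay, > 27000 nM. Compound 2 `CS(=O)(=O)c1ccc(C(=O)NCCC(=O)N2CCCCC2)cc1[N+](=O)[O-]` likewise sits at a limit of this assay, > 27000 nM. Within the data shown here, the one step with a stated size is an at least 2.5-fold lower number from compound 2 to compound 3 (0.41 log units; beyond the scatter), and its size is known only as a bound because of the limit of > 27000 nM in this assay, at which 2 of the 3 values shown sit.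

Compound 4 `CS(=O)(=O)c1ccc(C(=O)NCCC(=O)N2CCc3ccccc32)cc1[N+](=O)[O-]` differs from compound 3 in one place: 2,3-dihydro-1H-indol-1-yl in place of 1,2,3,4-tetrahydroquinolin-1-yl on a carbonyl carbon. Among the measured compounds shown here, no measured step covers this exchange; the single measured step, an at least 2.5-fold lower number from compound 2 to compound 3 (0.41 log units; beyond the scatter), concerns a different ring on the same carbonyl carbon, so it gives no direction for the present change. With nothing pointing either way, the expectation for compound 4 is a step of a 1.1-fold higher number from compound 3 to compound 4 (0.06 log units; within the scatter) within the usual scatter. Compound 4 is therefore estimated at 12000 nM, with a range from 5000 nM to 27000 nM, and a fair chance that this assay again returns only a limit.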

Compound 4, half-maximal effective concentration: > 27000 nM
Compound 4: no number, only a limit; the forecaster's own chance of this, stated with the estimate: 35%; middle value at least 2.2-fold (0.35 log units) away from the limit.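

On this carbonyl carbon, ring size in the fused group now shows up in this assay: 2,3-dihydro-1H-indol-1-yl in place of 1,2,3,4-tetrahydroquinolin-1-yl gives an at least 2.5-fold higher number from compound 3 to compound 4 (0.41 log units; beyond the scatter). Of the three groups compared on this carbon, only 1,2,3,4-tetrahydroquinolin-1-yl returns a number, so the fused aromatic ring alone does not bring a number back, as compound 4 shows. The step between compound 2 and compound 4 cannot be read, and the size of the step to compound 4 is only a bound: the limit of > 27000 nM in this assay, at which 3 of the 4 values shown sit.

From the compounds shown here alone, how far compound 2 and compound 4 differ beyond that limit remains open. Also open, going by these compounds, is whether an azepane or an open-chain N-methylaniline on the same carbonyl carbon would return a number in this assay.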